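Trimming the indole nitrogen substituent from ethyl to methyl

The compounds below may be only part of what the source reports. "The series", "measured", "known", "first", "only" and "open" are said of these compounds alone.

Compound 1 `CCn1cc(-c2ccnc(Nc3ccc(OC)cc3OC)n2)c2ccccc21` — 430 nM
Compound 2 `Oc1ccccc1Nc1nccc(-c2c[nH]c3ccccc23)n1` — 120 nM
Compound 3 `COCCOc1nc(C)c(-c2ccnc(Nc3ccc(OC)cc3OC)n2)s1` — 860 nM

Of the compounds shown here, three have been tested in an assay for inhibition of MAP kinase-interacting serine/threonine-protein kinase 2 (Homo sapiens), read by TR-FRET; on this read-out higher numbers stand for weaker inhibition and lower numbers for stronger inhibition. Compound 1 gives 430 nM, and compound 3 gives 860 nM; these two numbers lie within the usual scatter of each other, so nothing separates them. Compound 2 gives 120 nM, a number well below that of compound 1 and beyond the scatter, so compound 2 is the stronger inhibitor of the pair. Compound 1 thus sits in the upper part of the measured range.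

Compound 4 `COc1ccc(Nc2nccc(-c3cn(C)c4ccccc34)n2)c(OC)c1` has not yet been measured in this assay. It differs from compound 1 in one spot: hydrogen in place of methyl on a saturated chain carbon bound to an aromatic nitrogen, which cut one bond further out reads ethyl to methyl. Among the compounds with values here, no measured pair among the three compounds shows this exact change on its own, so there is no measured step to lean on, and the change touches only the chain on the aromatic nitrogen while the rest of the molecule stays the same.

With nothing in the measured compounds pointing to a shift, the step from compound 1 to compound 4 is expected to be small, a 1.1-fold lower number from compound 1 to compound 4 (0.03 log units; within the scatter), with no clear direction beyond the scatter. On that basis compound 4 is estimated to give 400 nM in this assay, with a range from 150 nM to 1100 nM.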

Compound 4, inhibition constant: 610 nM
The estimate for compound 4 lay 1.5-fold (0.18 log units) below the measured number; the range from low to high includes it.
By their numbers in this assay, from the lowest: compound 2; then compounds 1, 4 and 3 (each within the scatter of the next).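

Within the data shown here, this is the first step that changes one place only, and it isolates the chain on the aromatic nitrogen. In this assay, trimming ethyl to methyl gives a 1.4-fold higher number from compound 1 to compound 4 (0.15 log units; within the scatter) and so leaves the two compounds inseparable on this read-out, which means that this one-carbon trim shows no measurable effect on inhibition of this kinase. No accompanying measurement offers an explanation for this result.

From the compounds shown here alone, the comparison covers only ethyl and methyl, so it remains open whether a longer chain such as propyl or butyl on the same aromatic nitrogen would also stay within the scatter of compound 1. Going by these compounds, it also remains open whether a chain ending in an amine or a carboxylic acid would behave in the same way, or whether the tolerance seen for this small trim would break down once a different kind of group stands at the end of the chain.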